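This account rests on a few compounds, and the source may have more. Where it says the series, first, only, none or still open, it means among the compounds named here.

Measured compounds:
Compound 1 `O=[N+]([O-])c1ccc(NC(=S)OCCc2ccccn2)cc1` gives > 100000 nM in an ADME assay on MT4 cells (Homo sapiens) for cytotoxicity, read by MTT assay (a higher number here means that more compound is tolerated, a lower number that less compound is tolerated), which is a limit of the assay and not a number.
Compound 2 `COc1ccc(NC(=S)OCCc2ccccn2)cc1` gives 48000 nM in this assay.
Compound 3 `O=[N+]([O-])c1ccc(NC(=S)OCCc2ccncc2)cc1` gives > 100000 nM in this assay, again a limit of the assay.

Compound 4 `COc1ccc(NC(=S)OCCc2ccncc2)cc1` is not yet measured. Among the measured compounds shown here, the change from compound 3 to compound 4, (methoxy in place of nitro on an aromatic carbon), is the same change as the one from compound 1 to compound 2, (methoxy in place of nitro on an aromatic carbon), with the place described in the same words. That earlier change gave an at least 2.0-fold lower number from compound 1 to compound 2 (0.31 log units; beyond the scatter), a step that has to be read against (the limit of > 100000 nM in this assay, at which 2 of the 3 values shown sit). The two cores differ as pyridin-4-yl in place of pyridin-2-yl on a saturated chain carbon, two bonds along the chain from an oxygen on an unsaturated carbon; the step that the two limits leave unreadable from compound 1 to compound 3 cannot be sized from the two limits. For compound 4 a step of about an at least 2.2-fold lower number from compound 3 to compound 4 (0.34 log units; beyond the scatter) is expected, resting on an at least 2.0-fold lower number from compound 1 to compound 2 (0.31 log units; beyond the scatter). Compound 4 is estimated at 45000 nM, with an expected range from 20000 nM to 120000 nM.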

Compound 4, half-maximal cytotoxic concentration: 59000 nM
Beside the measured number, compound 4's estimate is 1.3-fold (0.12 log units) below it, within the range that was stated.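

In this assay, methoxy in place of nitro on the core of compound 3 gives an at least 1.6-fold lower number from compound 3 to compound 4 (0.22 log units; that floor lies within the scatter), so the change points the same way on both cores, though a match in size is not shown: the same change on two cores in this assay, an at least 2.0-fold lower number (0.31 log units; beyond the scatter) from compound 1 to compound 2 and an at least 1.6-fold lower number (0.22 log units; that floor lies within the scatter) from compound 3 to compound 4; the limit leaves it open whether they differ. Between the two methoxy compounds, the change of core gives a 1.2-fold higher number from compound 2 to compound 4 (0.09 log units; within the scatter), while the step between the two nitro compounds cannot be read. Neither nitro step has a true size, as both nitro compounds stand at a limit of the assay: the limit of > 100000 nM in this assay, at which 2 of the 4 values shown sit.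

Still open, from the compounds shown here alone, is whether the change carries over when an amine or a carboxylic acid takes the place of nitro on the aromatic ring. Going by these compounds, the effect of a longer chain on either core also remains open.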